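A few compounds are considered here, and "the series" means these few. Any claim that something is new, unique, unknown or untested is made for them only; others in the source may bear on it.

Measured so far in an ADME assay on MT4 cells (Homo sapiens) for cytotoxicity, read by MTT assay, with a stated time of 5 days; on this read-out lower numbers stand for higher toxicity in this test and higher numbers for lower toxicity in this test:
compound 1 `N#Cc1ccc(Nc2nccc(Oc3ccc(C(=O)c4ccc(O)cc4)cc3)n2)cc1`, 19400 nM
compound 2 `Cc1cc(Oc2ccc(C(=O)c3ccc(O)cc3)cc2)nc(Nc2ccc(C#N)cc2)n1`, 32000 nM

Of the two numbers, that of compound 2 is the higher, but the step of a 1.6-fold higher number from compound 1 to compound 2 (0.22 log units; within the scatter) is within the scatter, so compound 1 and compound 2 do not separate on this read-out.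

Compound 3 `COCCc1ccc(Oc2cc(C)nc(Nc3ccc(C#N)cc3)n2)cc1` has not been measured. It differs from compound 2 in one place: 2-methoxyethyl in place of (4-hydroxyphenyl)carbonyl on an aromatic carbon. For the measured compounds named here, the only measured step, from compound 1 to compound 2, concerns a methyl and does not bear on this change; no measured pair shows what exchanging the (4-hydroxyphenyl)carbonyl for a 2-methoxyethyl does in this assay. With nothing in the data pointing either way, the step of a 1.1-fold lower number from compound 2 to compound 3 (0.03 log units; within the scatter) is expected to remain within the scatter. Compound 3 is therefore estimated at 30000 nM, with a range from 10000 nM to 90000 nM.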

Compound 3, half-maximal cytotoxic concentration: 13800 nM
Beside the measured number, compound 3's estimate is 2.2-fold (0.34 log units) above it; the range from low to high includes it.
By their numbers in this assay, from the lowest: compounds 3, 1 and 2 (each within the scatter of the next, the first and the last beyond it).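

In this assay, the aromatic carbon bearing this substituent proves sensitive to what is attached there: a 2.3-fold lower number from compound 2 to compound 3 (0.37 log units; beyond the scatter), a modest move towards higher toxicity in this test. Unlike the methyl change, this exchange of (4-hydroxyphenyl)carbonyl for 2-methoxyethyl gives a step beyond the scatter, and it is the first such step between compounds differing in one place. No measurement available here bears on what lies behind this step.

On these data alone, the exchange removes the aromatic ring, the carbonyl and the hydroxyl together and introduces the ether chain, so the share of each in the step remains open. Also open, as far as these compounds go, is how a longer chain, a carboxylic acid or an amine at this carbon would read on this scale.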